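Urea series: removing the bromo from compound 3

The compounds below may be only part of what the source reports. "The series", "measured", "known", "first", "only" and "open" are said of these compounds alone.

The shared core carries a urea whose far nitrogen is varied. Compound 1 `CCOc1ccc(NC(=O)Nc2cccc(CNc3nccnc3Cl)c2)cc1` bears 4-ethoxyphenyl there and in a functional assay on MGC-803 cells (Homo sapiens) for antiproliferative activity, read by MTT assay, with a stated time of 48 h (a higher number here means a weaker inhibitor, a lower number a stronger inhibitor), compound 1 gives 7240 nM. Compound 3 `O=C(Nc1cccc(CNc2nccnc2Cl)c1)Nc1ccc(Cl)cc1Br` bears 2-bromo-4-chlorophenyl, and in this assay compound 3 gives 7480 nM; the step of a 1.0-fold higher number from compound 1 to compound 3 (0.01 log units; within the scatter) lies within the scatter, so the two aryl ureas sit together. Compound 2 `O=C(Nc1cccc(CNc2nccnc2Cl)c1)NC1CCCCC1` bears cyclohexyl, and in this assay compound 2 reaches only the limit > 40000 nM (the limit of > 40000 nM in this assay, at which 1 of the 3 values shown sits). The steps of an at least 5.5-fold higher number from compound 1 to compound 2 (0.74 log units; beyond the scatter) and an at least 5.3-fold lower number from compound 2 to compound 3 (0.72 log units; beyond the scatter) show that exchanging the aryl group for cyclohexyl costs, while the two aryl substitution patterns do not differ.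

Compound 4 `O=C(Nc1ccc(Cl)cc1)Nc1cccc(CNc2nccnc2Cl)c1` differs from compound 3 by hydrogen in place of bromo on an aromatic carbon. The step that bears on it, a 1.0-fold higher number from compound 1 to compound 3 (0.01 log units; within the scatter), says that changing substituents on the aryl urea left the number unchanged; the aryl-to-cyclohexyl steps do not apply here since the ring stays. No step beyond the scatter is therefore expected, a 1.0-fold higher number from compound 3 to compound 4 (0.00 log units; within the scatter). Compound 4 is estimated at 7500 nM, within 3500 nM to 16000 nM.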

Compound 4, half-maximal inhibitory concentration: 4980 nM
The estimate for compound 4 lay 1.5-fold (0.18 log units) above the measured number, within the range that was stated.
By their numbers in this assay, from the lowest: compounds 4, 1 and 3 (each within the scatter of the next). At a limit, above all of these: compound 2.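

In this assay, taking off the bromo, ortho to a large group, gives a 1.5-fold lower number from compound 3 to compound 4 (0.18 log units; within the scatter), so this ring does not depend on the bromo for its number here. With the bromo gone, the two rings differ only in one group, and a 1.5-fold lower number from compound 1 to compound 4 (0.16 log units; within the scatter) leaves the 4-chlorophenyl and 4-ethoxyphenyl ureas not separated. The 4-chlorophenyl urea also keeps the gap to cyclohexyl, an at least 8.0-fold lower number from compound 2 to compound 4 (0.90 log units; beyond the scatter), a step that starts from a limit and not a number: the limit of > 40000 nM in this assay, at which 1 of the 4 values shown sits.

The compounds shown leave open whether the ring keeps its number with hydrogen, an amine or a carboxylic acid in place of the chloro. They also leave open whether a longer chain in place of cyclohexyl would fare any better.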